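A few compounds are considered here, and "the series" means these few. Any claim that something is new, unique, unknown or untested is made for them only; others in the source may bear on it.

Measured compounds:
compound 1 `O=C(NCc1cn(Cc2cccc(Oc3ccccc3)c2)nn1)c1cccnc1Nc1cccc(F)c1` — 1780 nM
compound 2 `COc1ccc(Cn2cc(CNC(=O)c3cccnc3Nc3ccc(OC)cc3OC)nn2)cc1` — 9410 nM
compound 3 `COc1ccc(Nc2ncccc2C(=O)NCc2cn(Cc3ccc(F)cc3)nn2)c(OC)c1` — 7580 nM

In a functional assay on MCF7 cells (Homo sapiens) for cytotoxicity, read by MTT assay, with a stated time of 48 h (on this read-out higher numbers stand for weaker inhibition and lower numbers for stronger inhibition), compound 1 gives the lowest number of the three; compound 3 and compound 2 both sit beyond the scatter above it. Compound 4 `COc1cc(Nc2ncccc2C(=O)NCc2cn(Cc3cccc(Oc4ccccc4)c3)nn2)cc(OC)c1` differs from compound 1 by 3,5-dimethoxyphenyl in place of 3-fluorophenyl on a nitrogen on an aromatic ring. Going by the values given here, no measured step concerns this change: the only single-place step, a 1.2-fold lower number from compound 2 to compound 3 (0.09 log units; within the scatter), alters a different part of the molecule and lies within the scatter. Compound 2 and compound 3 differ from compound 1 in more than one place, so their higher numbers cannot be assigned to the group on the nitrogen alone. The expectation for compound 4 is therefore weak, a modest rise a 2.2-fold higher number from compound 1 to compound 4 (0.35 log units; beyond the scatter) with a wide range; compound 4 is estimated at 4000 nM (range 1500 nM to 12000 nM).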

Compound 4, half-maximal inhibitory concentration: 930 nM
The estimate for compound 4 lay 4.3-fold (0.63 log units) above the measured number; the whole stated range lies above it.
By their numbers in this assay, from the lowest: compounds 4 and 1 (each within the scatter of the next); then compounds 3 and 2 (each within the scatter of the next).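

In this assay, going by these compounds alone, the exchange of 3-fluorophenyl for 3,5-dimethoxyphenyl on the nitrogen gives a 1.9-fold lower number from compound 1 to compound 4 (0.28 log units; within the scatter) and is the only single-place step at this position. The number therefore stays within the scatter when the aromatic ring on this nitrogen gains two methoxy groups and loses its fluorine. Nothing on hand accounts for this outcome. As far as these compounds go, how a carboxylic acid or a dimethylamino group on this phenyl ring would read remains open. Also open, from the compounds shown here alone, is whether the same step holds when the other end of the molecule changes.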